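This account rests on a few compounds, and the source may have more. Where it says the series, first, only, none or still open, it means among the compounds named here.

Compound 1, `COc1cc(Nc2nc(C)cc(N(C)C)n2)ccc1F`: compound 1 gives > 250000 nM in a physicochemical assay for solubility, read by nephelometry, measured as kinetic solubility; a higher number here means a more soluble compound, a lower number a less soluble compound.
Compound 2, `COc1cc(Nc2nc(CO)cc(N(C)C)n2)ccc1F`: compound 2 gives > 250000 nM in this assay.

For compound 1 the value is a limit of this assay, not a number. For compound 2 the value is likewise a limit of this assay. The step that the two limits leave unreadable from compound 1 to compound 2 is therefore unreadable, since both ends sit at the same limit (the limit of > 250000 nM in this assay, at which 2 of the 2 values shown sit). Where compound 2 stands can be said only to that extent: at the limit, as does the one other value shown.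

Compound 3, `COc1cc(Nc2nc(C(=O)N3CCCC3)cc(N(C)C)n2)ccc1F`, differs from compound 2 by (pyrrolidin-1-yl)carbonyl in place of hydroxymethyl on an aromatic carbon. Among the measured compounds shown here, no measured step bears on this change: the one step measured is unreadable in size, and no other pair in this set involves the groups that leave or enter. Any expectation for compound 3 in this assay thus rests only on compound 2 standing at the limit. Compound 3 is expected to remain soluble, estimated at 150000 nM (range 30000 nM to 250000 nM), an expected step of an at least 1.6-fold lower number from compound 2 to compound 3 (0.22 log units; that floor lies within the scatter), with a fair chance that this assay again reports only a limit.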

Compound 3, solubility: > 250000 nM
Compound 3 ended at the assay's limit; the forecaster's own chance of this, stated with the estimate: 50%; middle value at least 1.6-fold (0.22 log units) from the limit.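

Among the compounds shown here, compound 3, like compound 1 and compound 2, stands at a limit of this assay and not at a number, so no step among the three can be read: the limit of > 250000 nM in this assay, at which 3 of the 3 values shown sit.

The compounds shown leave open how far each one lies past this limit, and so whether methyl, hydroxymethyl or (pyrrolidin-1-yl)carbonyl at this place makes any difference to the read-out.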